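Cytotoxicity notes: open-chain amine analogue of compound 1

The source may hold more compounds than are shown below. What is called first, only, known or untested is meant among the compounds shown, and "the series" means these compounds.

Compound 1 `O=C(CN1CCCC1)OC1CC2(N3CCCCC3)CC(c3ccccc3)C1C(c1ccccc1)C2`, compound 2 `CN(C)C12CC(N)C(C(c3ccccc3)C1)C(c1ccccc1)C2` and compound 3 `CN1CCN(CC(=O)NC2CC3(N4CCCC4)CC(c4ccccc4)C2C(c2ccccc2)C3)CC1` share a core and have each been run in an ADME assay on L6 cells (Rattus norvegicus) for cytotoxicity, read by resazurin assay, with a stated time of 72 h; a lower number here means a stronger inhibitor, a higher number a weaker inhibitor. Compound 1 gives 16400 nM, compound 2 gives 40900 nM and compound 3 gives 50200 nM. Compound 1 therefore stands lowest of the three numbers; its nearest neighbour is compound 2 and its furthest is compound 3, and both gaps lie beyond the usual scatter, so compound 1 is the strongest inhibitor of the three in this assay.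

Compound 4 `CCN(CC)CC(=O)OC1CC2(N3CCCCC3)CC(c3ccccc3)C1C(c1ccccc1)C2` has not yet been measured. It differs from compound 1 in one place: diethylamino in place of pyrrolidin-1-yl on a saturated chain carbon bound to a carbonyl carbon. Among the measured compounds shown here, no pair of measured compounds carries this change, so the expectation rests on compound 1 alone, and the two groups exchanged are counted as equal in heavy atoms and in acceptors. The step from compound 1 to compound 4 in this assay is expected to be small, a 1.1-fold higher number from compound 1 to compound 4 (0.04 log units; within the scatter), in no direction beyond the scatter. Compound 4 is thus estimated at 18000 nM, within a range from 8000 nM to 40000 nM.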

Compound 4, half-maximal inhibitory concentration: 23900 nM
Compound 4: the middle estimate sits 1.3-fold (0.12 log units) below what was measured, within the range that was stated.
By their numbers in this assay, from the lowest: compounds 1, 4, 2 and 3 (each within the scatter of the next, the first and the last beyond it).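

Diethylamino in place of pyrrolidin-1-yl, on a saturated chain carbon bound to a carbonyl carbon, provides the first one-place step in the series in this assay (a 1.5-fold higher number from compound 1 to compound 4 (0.16 log units; within the scatter)). This step lies within the scatter, so opening the ring at this position, with the heavy-atom and acceptor counts unchanged, does not separate compound 4 from compound 1. This rests on a single pair, and no supporting measurement offers an explanation for the step.

On these data alone, whether the position tolerates other amines, such as dimethylamino or morpholin-4-yl, remains open. Also open, as far as these compounds go, is whether a longer chain carrying the diethylamino group, or an amide in place of the ester of compound 4, would stay within the scatter.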